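The source may report more compounds than this note shows. Statements on the series, on what has been measured and on what is new or still open speak of the compounds shown alone.

In an ADME assay on a cell-free system (plasma, Homo sapiens) for metabolic stability, read by LC-MS (a higher number here means that the compound lasts longer, a lower number that the compound disappears faster), compound 1 `COc1ccc2c(c1)c(CC(=O)OCCOc1ccc3oc(=O)ccc3c1)c(C)n2C(=O)c1ccc(Cl)cc1` gives > 4 h as a limit, not a number. Compound 2 `CC(C)Cc1ccc(C(C)C(=O)OCCOc2ccc3oc(=O)ccc3c2)cc1` gives > 4 h as a limit too. Compound 3 `COc1ccc2cc([C@H](C)C(=O)OCCOc3ccc4oc(=O)ccc4c3)ccc2c1` gives > 4 h as a limit too. For the measured compounds named here, compound 1 thus shares its standing with both others, as the limit of > 4 h in this assay, at which 3 of the 3 values shown sit, shows, and no measured step is available. Compound 4 `COc1ccc2c(c1)c(CC(=O)OCCOc1ccc3ccc(=O)oc3c1)c(C)n2C(=O)c1ccc(Cl)cc1` has the same atoms as compound 1, joined differently: a group of 11 heavy atoms (9 carbon, 2 oxygen; one six-membered aromatic ring of carbon only, one six-membered aromatic ring with 1 hetero atom) in place of a group of 11 heavy atoms (9 carbon, 2 oxygen; one six-membered aromatic ring of carbon only, one six-membered aromatic ring with 1 hetero atom), on an oxygen on a saturated carbon applies on an oxygen on a saturated carbon. With only limits to go on, no step beyond the scatter is expected in this assay and no direction is expected. The estimated step that the limit leaves unreadable from compound 1 to compound 4 stays inside the scatter. For compound 4 the expected half-life is 5 h with an estimated range from 2.5 h to 8 h on repeat measurement.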

Compound 4, half-life: > 4 h
Compound 4: no number, only a limit; the forecaster's own chance of this, stated with the estimate: 70%; the middle value lies beyond the limit too.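

For the compounds shown here, no step from compound 1 to compound 4 can be read in this assay, because both values are limits: the limit of > 4 h in this assay, at which 4 of the 4 values shown sit. Going by these compounds, how far the half-lives of compound 1, compound 2, compound 3 and compound 4 extend past that limit, and whether they differ, stays open.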